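This account rests on a few compounds, and the source may have more. Where it says the series, first, only, none or still open, it means among the compounds named here.

In a functional assay on DU-145 cells (Homo sapiens) for inhibition, read by trypan blue exclusion, with a stated time of 96 h (a higher number here means a weaker inhibitor of growth, a lower number a stronger inhibitor of growth), compound 1 `O=C(O)c1cc(/C=C(\C(=O)c2c(F)c(F)c(F)c(F)c2F)S(=O)(=O)c2ccc(Br)cc2)ccc1O` gives > 100000 nM, which is a limit and not a number. Compound 2 `O=C(/C(=C\c1ccc([N+](=O)[O-])c(O)c1)S(=O)(=O)c1ccc(Br)cc1)c1c(F)c(F)c(F)c(F)c1F` gives 1000 nM in this assay.

Compound 3 `O=C(O)c1cc(/C=C(/Sc2ccc(Br)cc2)C(=O)c2c(F)c(F)c(F)c(F)c2F)ccc1O` is changed at a different place: (4-bromophenyl)sulfanyl in place of (4-bromophenyl)sulfonyl on a double-bonded chain carbon bound to a carbonyl carbon and a double-bonded chain carbon. In words, it has (4-bromophenyl)sulfanyl in place of (4-bromophenyl)sulfonyl on a double-bonded chain carbon bound to a carbonyl carbon and a double-bonded chain carbon. Going by the values given here, no measured step touches this place, so the data give no direct size for the change.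

Among the compounds with values here, the only measured step, an at least 100-fold lower number from compound 1 to compound 2 (2.00 log units; beyond the scatter), is large and beyond the scatter, but it exchanges 3-carboxy-4-hydroxyphenyl for 3-hydroxy-4-nitrophenyl. Compound 3 keeps the 3-carboxy-4-hydroxyphenyl group, so that step offers no support for a similar gain, though it does show that one change on the shared core can move the number greatly.

A modest move toward a lower number in this assay is therefore expected, and the estimated step is an at least 1.6-fold lower number from compound 1 to compound 3 (0.22 log units; that floor lies within the scatter). The assay may again report only a limit. For compound 3 the estimated value is 60000 nM, with an expected range from 8000 nM to 150000 nM.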

Compound 3, concentration for 50% growth inhibition: 25000 nM
For compound 3 the middle estimate is 2.4-fold (0.38 log units) above the measured one, within the range that was stated.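

In this assay, the exchange of (4-bromophenyl)sulfonyl for (4-bromophenyl)sulfanyl gives an at least 4.0-fold lower number from compound 1 to compound 3 (0.60 log units; beyond the scatter). Going by these compounds alone, this is the first measured sign that the place on a double-bonded chain carbon bound to a carbonyl carbon and a double-bonded chain carbon also moves the number, and it does so with the 3-carboxy-4-hydroxyphenyl group kept, so the change seen with compound 2 is not the only route away from the limit on this core. The step can be read only as a floor, and its full size stays unknown because compound 1 stands only at a limit: the limit of > 100000 nM in this assay, at which 1 of the 3 values shown sits.

The compounds shown do not tell whether the same exchange would move the number on a core carrying the 3-hydroxy-4-nitrophenyl group of compound 2, where the starting point is a measured value and not a limit. They also leave open how a 4-bromophenyl ring attached at this place through a sulfinyl group, an ether oxygen or an amine would read, so the trend from sulfonyl to sulfanyl rests on a single pair.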